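The source may report more compounds than this note shows. Statements on the series, on what has been measured and on what is new or still open speak of the compounds shown alone.

For the measured compounds named here, compound 3 `O=c1ccoc2cc(OCc3cn(Cc4ccccc4F)nn3)ccc12` is the only member of this small set to return a number in a functional assay on MDA-MB-231 cells (Homo sapiens) for cytotoxicity, read by MTT assay, with a stated time of 48 h (on this read-out lower numbers stand for stronger inhibition and higher numbers for weaker inhibition), where compound 3 gives 29800 nM. Compound 1 `CC(C)(C)c1ccc(Cn2cc(COc3ccc4c(=O)ccoc4c3)nn2)cc1` reaches only a limit of this assay, > 100000 nM. Compound 2 `O=c1ccoc2cc(OCc3cn(Cc4ccc(F)cc4)nn3)ccc12` likewise stops at a limit, > 100000 nM. With both ends capped, the step that the two limits leave unreadable from compound 1 to compound 2 cannot be read. Going by the values given here, the one readable step is an at least 3.3-fold lower number from compound 2 to compound 3 (0.52 log units; beyond the scatter), and it shows that exchanging 4-fluorophenyl for 2-fluorophenyl pulled the number down out of the limit.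

Compound 4 `COc1ccc(Cn2cc(COc3ccc4c(=O)ccoc4c3)nn2)cc1` undoes that arrangement: 4-methoxyphenyl in place of 2-fluorophenyl on a saturated chain carbon bound to an aromatic nitrogen. The 4-methoxyphenyl restores the substitution seen in the 4-fluorophenyl of compound 2, so the step that bears on it is the reverse of an at least 3.3-fold lower number from compound 2 to compound 3 (0.52 log units; beyond the scatter). Because two of the three measured compounds sit at the limit of > 100000 nM in this assay, at which 2 of the 3 values shown sit, the change is expected to carry the number back up toward that limit, though a methoxy group has not been tested in this core and the size of the rise is uncertain. The expected step is therefore a 3.4-fold higher number from compound 3 to compound 4 (0.53 log units; beyond the scatter). Compound 4 is estimated at 100000 nM, with a range from 30000 nM to 300000 nM.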

Compound 4, half-maximal inhibitory concentration: > 100000 nM
Compound 4: no number, only a limit (the forecaster's own chance of this, stated with the estimate: 55%); the middle value lies on the limit itself.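

The change to 4-methoxyphenyl on a saturated chain carbon bound to an aromatic nitrogen gives an at least 3.3-fold higher number from compound 3 to compound 4 (0.52 log units; beyond the scatter). For the compounds shown here, until now, the only readable step at this place had set 2-fluorophenyl against 4-fluorophenyl, so a single group stood as the comparison; compound 4 adds a second, one that carries no fluorine and brings an oxygen. Of the four groups shown at this place, only the 2-fluorophenyl of compound 3 returns a number in this assay, and compound 1, compound 2 and compound 4 all stop at the same limit: the limit of > 100000 nM in this assay, at which 3 of the 4 values shown sit.

From the compounds shown here alone, the steps among compound 1, compound 2 and compound 4 cannot be read, as each joins two limits, so the order of these three remains unknown. Going by these compounds, it also remains open whether the number of compound 3 depends on fluorine itself or on the 2-fluorophenyl arrangement, a question that a chlorophenyl or an unsubstituted phenyl at this place would help to settle.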